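Removing the methyl from a methoxy group: expected effect on cytotoxicity

The compounds below may be only part of what the source reports. "The series", "measured", "known", "first", "only" and "open" are said of these compounds alone.

Measured compounds:
compound 1, `Cc1cc(O)cc(-c2nn(CC#N)cc2-c2ccnc(-c3ccc(Oc4ccccc4)cc3)c2)c1`: 30%
compound 2, `COc1cc(C)cc(-c2nn(CC#N)cc2-c2ccnc(-c3ccc(N(C)C)cc3)c2)c1`: -12%

Of the compounds shown here, two sharing one core have been tested in a functional assay on SNB-75 cells (Homo sapiens) for cytotoxicity, read by sulforhodamine B assay, with a stated time of 48 h, tested at 1 uM; on this read-out higher numbers stand for a weaker effect at the one concentration tested and lower numbers for a stronger effect. Compound 1 gives 30% in this assay, and compound 2 gives -12% in this assay. Compound 2 therefore holds the lowest of the two numbers, and its nearest neighbour, compound 1, sits a distance above it that lies beyond the usual scatter of this measurement. The two compounds differ in more than one place, so no single structural change can be tied to that gap.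

Compound 3, `Cc1cc(O)cc(-c2nn(CC#N)cc2-c2ccnc(-c3ccc(N(C)C)cc3)c2)c1`, has not yet been measured in this assay. It is made from compound 2 by one change: hydrogen in place of methyl on an oxygen on an aromatic ring. Among the compounds with values here, no pair of measured compounds shows the effect of this exact change, so there is no measured step to lean on. A step of small size is expected, with no clear direction, most likely within the scatter, so that the value of compound 3 is expected to stay close to that of compound 2, as a number 10 percentage points higher from compound 2 to compound 3 (within the scatter). Compound 3 is thus estimated at -2%, with a range from -25% to 25%.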

Compound 3, a percentage reported as activity, at one concentration (the size of the read-out at that concentration, not a potency): -22%
The estimate for compound 3 lay 20 percentage points above the measured number; the range from low to high includes it.
By their numbers in this assay, from the lowest: compounds 3 and 2 (each within the scatter of the next); then compound 1.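

In this assay, within the data shown here, the change from methoxy to hydroxy on the 3-methoxy-5-methylphenyl group gives the first measured step at this position, a number 10 percentage points lower from compound 2 to compound 3 (within the scatter) and so the two compounds cannot be told apart at the one concentration tested. Compound 3 also opens a second single-place comparison, dimethylamino in place of phenoxy on an aromatic carbon, which gives a number 52 percentage points lower from compound 1 to compound 3 (beyond the scatter) and marks a clear gain in effect. Among these compounds, of the two single changes now measured, only this exchange of phenoxy for dimethylamino carries a step beyond the scatter, while the hydrogen or methyl on the oxygen makes no clear difference here.

No available measurement explains either step. The compounds shown leave open whether a longer chain on that oxygen, such as ethoxy, or an amine in place of the hydroxy would also stay within the scatter, and whether another amine, such as morpholine, could stand in for dimethylamino and keep the stronger effect.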